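Adding one hydroxy to compound 3

The source may hold more compounds than are shown below. What is called first, only, known or untested is meant among the compounds shown, and "the series" means these compounds.

Compound 1 `COc1ccc(-c2sc(C(=O)O)cc2-c2cc(OC)c(OC)c(OC)c2)cc1O` gives 11200 nM (a measured number)
Compound 2 `COc1cc(-c2ccsc2-c2cccc(Br)c2)cc(OC)c1OC` gives > 100000 nM (a limit of the assay, not a number)
Compound 3 `CCOC(=O)c1cc(-c2ccc(OC)cc2)c(-c2cc(OC)c(OC)c(OC)c2)s1` gives 10200 nM (a measured number)

In a functional assay on KB cells (Homo sapiens) for antiproliferative activity, read by MTT assay, with a stated time of 72 h (a higher number here means a weaker inhibitor, a lower number a stronger inhibitor), compound 3 gives 10200 nM and compound 1 gives 11200 nM (two numbers within the usual scatter of each other). For compound 2 the assay reports only the limit > 100000 nM and no number.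

Compound 4 `CCOC(=O)c1cc(-c2ccc(OC)c(O)c2)c(-c2cc(OC)c(OC)c(OC)c2)s1` differs from compound 3 by one change: hydroxy in place of hydrogen on an aromatic carbon (hydroxy in place of hydrogen on an aromatic carbon, ortho to a methoxy group and meta to a large group). The 4-methoxyphenyl thus becomes 3-hydroxy-4-methoxyphenyl.

Within the data shown here, no measured step shows what this change does, so any forecast is loose. Compound 1 also carries 3-hydroxy-4-methoxyphenyl and gives 11200 nM (not a strong result), so a very large gain is not assumed. The expected change is a 4.1-fold lower number from compound 3 to compound 4 (0.61 log units; beyond the scatter) in this assay and points to a moderately stronger inhibitor. Compound 4 is expected at 2500 nM (estimated range 300 nM to 12000 nM).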

Compound 4, half-maximal inhibitory concentration: > 100000 nM
Compound 4 gave a limit, no number; the forecaster's own chance of this, stated with the estimate: 5%; at least 40-fold (1.60 log units) between middle value and limit.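

In this assay, hydroxy in place of hydrogen on an aromatic carbon, ortho to a methoxy group, gives an at least 9.8-fold higher number from compound 3 to compound 4 (0.99 log units; beyond the scatter), so at this position the change weakens the compound rather than strengthening it. Compound 4 has an ethyl ester where compound 1, which carries the same 3-hydroxy-4-methoxyphenyl, has a carboxylic acid, and compound 1 gives 11200 nM, so this group alone does not rule out a measured number. Compound 4 gives only a limit and no number, so the full size of the loss cannot be read, and it now sits with compound 2: the limit of > 100000 nM in this assay, at which 2 of the 4 values shown sit.

As far as these compounds go, whether this position accepts any other group, such as an amine or a fluorine, stays open. Also open, from the compounds shown here alone, is whether moving the hydroxy to another carbon of this ring would give a measurable number.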